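Swapping a Fluoro for a Trifluoroacetamide Group

The source may report more compounds than this note shows. Statements on the series, on what has been measured and on what is new or still open speak of the compounds shown alone.

Of the compounds shown here, three sharing one core have been measured in an assay on mitochondria from L6 cells (Rattus norvegicus) for activation, with a stated time of 90 min; on this read-out higher numbers stand for an effect only at larger amounts of compound and lower numbers for an effect already at smaller amounts. Compound 1 `Fc1ccc(Nc2nc3nonc3nc2Nc2ccccc2F)cc1` gives 2300 nM, the second highest of the three numbers. Compound 2 `Cc1cccc(Nc2nc3nonc3nc2Nc2ccccc2F)c1` gives 1500 nM, with a 1.5-fold lower number from compound 1 to compound 2 (0.19 log units; within the scatter). Compound 3 `CCOc1ccccc1Nc1nc2nonc2nc1Nc1ccccc1F` gives 5600 nM, with a 2.4-fold higher number from compound 1 to compound 3 (0.39 log units; beyond the scatter) and a 3.7-fold higher number from compound 2 to compound 3 (0.57 log units; beyond the scatter). Compound 4 `O=C(Nc1ccc(Nc2nc3nonc3nc2Nc2ccccc2F)cc1)C(F)(F)F` carries a change on compound 1: ((trifluoromethyl)carbonyl)amino in place of fluoro on an aromatic carbon. Among the measured compounds shown here, no measured step tries this replacement; the two steps from compound 1 exchange the whole ring and stay within the scatter or reach only a modest size. For compound 4 in this assay the expected step is a 1.1-fold higher number from compound 1 to compound 4 (0.04 log units; within the scatter), probably not beyond the scatter. Compound 4 is therefore estimated at 2500 nM, in the range 1000 nM to 7000 nM.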

Compound 4, half-maximal effective concentration: 4100 nM
The estimate for compound 4 lay 1.6-fold (0.21 log units) below the measured number; the range from low to high includes it.
By their numbers in this assay, from the lowest: compounds 2, 1, 4 and 3 (each within the scatter of the next, the first and the last beyond it).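

In this assay, the first change made on this aromatic carbon itself, ((trifluoromethyl)carbonyl)amino in place of fluoro, gives a 1.8-fold higher number from compound 1 to compound 4 (0.25 log units; within the scatter) and so stays within the usual scatter. At this position, para to a large group, a single fluorine can thus give way to a group of 7 heavy atoms, with a hydrogen-bond donor and acceptor, without a clear shift in the number. Nothing measured here bears on the reason for this result. Still open, as far as these compounds go, is how an amine, a carboxylic acid or a longer chain on this same carbon would behave. Also open, from the compounds shown here alone, is whether an acetylamino group, lacking the three fluorines, would give a similar number.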